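The source may report more compounds than this note shows. Statements on the series, on what has been measured and on what is new or still open speak of the compounds shown alone.

In a functional assay on MDA-MB-231 cells (Homo sapiens) for inhibition, read by MTT assay, with a stated time of 48 h (a lower number here means a stronger inhibitor of growth, a higher number a weaker inhibitor of growth), compound 1 `NS(=O)(=O)c1ccc(NC(=S)Nc2ccc3ncnc(Nc4cccc(Br)c4)c3c2)cc1` reads > 30000 nM, which is a limit of the assay and not a number (the limit of > 30000 nM in this assay, at which 1 of the 2 values shown sits). Among the measured compounds shown here, compound 2 `S=C(Nc1ccc(Cl)c(Cl)c1)Nc1ccc2ncnc(Nc3cccc(Br)c3)c2c1` gives 4800 nM, the only true number so far. Compound 3 `S=C(Nc1cccnc1)Nc1ccc2ncnc(Nc3cccc(Br)c3)c2c1` carries pyridin-3-yl in place of 3,4-dichlorophenyl on an amide-type nitrogen. For the measured compounds named here, one measured step bears on this place: an at least 6.2-fold lower number from compound 1 to compound 2 (0.79 log units; beyond the scatter), with 3,4-dichlorophenyl in place of 4-sulfamoylphenyl. Leaving 3,4-dichlorophenyl is therefore expected to give a higher number in this assay, by a modest step. The expected change is a 2.9-fold higher number from compound 2 to compound 3 (0.46 log units; beyond the scatter). For compound 3 the estimated value is 14000 nM, with an expected range of 5000 nM to 40000 nM.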

Compound 3, concentration for 50% growth inhibition: > 30000 nM
Compound 3 was reported as a limit (the forecaster's own chance of this, stated with the estimate: 35%); at least 2.1-fold (0.33 log units) between middle value and limit.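

At the amide-type nitrogen, pyridin-3-yl in place of 3,4-dichlorophenyl gives, in this assay, an at least 6.2-fold higher number from compound 2 to compound 3 (0.79 log units; beyond the scatter). Compound 3 reads as a limit and not a number, so both non-chlorinated groups at this place, 4-sulfamoylphenyl and pyridin-3-yl, now end at the same limit, and only 3,4-dichlorophenyl gives a true number: the limit of > 30000 nM in this assay, at which 2 of the 3 values shown sit. The step linking compound 1 and compound 3 cannot be read, as both values are limits. Going by these compounds, how a plain phenyl, a benzyl or a cyclohexyl would read at this place remains open, as does whether one chlorine alone would keep the true number of compound 2.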